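A few compounds are considered here, and "the series" means these few. Any claim that something is new, unique, unknown or untested is made for them only; others in the source may bear on it.

Working notes on the stereoisomer set in an assay for inhibition of alpha-N-acetylgalactosaminidase (Gallus gallus), tested at 1000 uM; a lower number here means less inhibition, a higher number more inhibition at the concentration tested (going by the name of the read-out).

Compound 1 `O=C(O)[C@H]1NC[C@@H](O)[C@H](O)[C@H]1O` gives 4.2%. Compound 2 `O=C(O)[C@@H]1NC[C@@H](O)[C@@H](O)[C@H]1O` gives 8.2%, and compound 3 `O=C(O)[C@H]1NC[C@@H](O)[C@H](O)[C@@H]1O` gives 11%. Compound 3 holds the highest of the three numbers, but the gaps are small: a number 6.8 percentage points higher from compound 1 to compound 3 (within the scatter) and a number 2.8 percentage points higher from compound 2 to compound 3 (within the scatter) both fall within the scatter, as does a number 4 percentage points higher from compound 1 to compound 2 (within the scatter). Each of these steps is a change of configuration alone, with the same atoms and bonds throughout the fact that compounds 1 and 2 differ only in the configuration as drawn the fact that compounds 1 and 3 differ only in the configuration as drawn (the fact that compounds 2 and 3 differ only in the configuration as drawn), and none of them moves this assay beyond its noise.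

Compound 4 `O=C(O)[C@@H]1NC[C@@H](O)[C@H](O)[C@@H]1O` is a fourth isomer of the shared core. the two compounds have the same atoms and bonds and differ only in configuration as drawn: 1 of 4 stereo elements differ; a stereocentre at a saturated ring carbon is drawn S in compound 3 and R in compound 4 The measured step of the same kind, a single stereocentre inverted, is a number 6.8 percentage points higher from compound 1 to compound 3 (within the scatter), and the two-centre and three-centre changes gave a number 4 percentage points higher from compound 1 to compound 2 (within the scatter) and a number 2.8 percentage points higher from compound 2 to compound 3 (within the scatter). On that evidence no step beyond the scatter is expected in this assay in either direction. The step of a number 3 percentage points lower from compound 3 to compound 4 (within the scatter) is expected to stay within the scatter. Compound 4 is estimated at 8%, between 0% and 18%.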

Compound 4, a percentage reported as inhibition, at one concentration (the size of the read-out at that concentration, not a potency): 10%
For compound 4 the middle estimate is 2 percentage points below the measured one; low and high end bracket the measured number.
By their numbers in this assay, from the lowest: compounds 1, 2, 4 and 3 (each within the scatter of the next).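

A second single-centre inversion gives a number 1 percentage points lower from compound 3 to compound 4 (within the scatter), so this change of one stereocentre from S to R also stays inside the noise of this assay: the fact that compounds 3 and 4 differ only in the configuration as drawn The two two-centre changes added by the new isomer give a number 1.8 percentage points higher from compound 2 to compound 4 (within the scatter) and a number 5.8 percentage points higher from compound 1 to compound 4 (within the scatter). All pairs among the four isomers now lie within the scatter, so no configuration shown separates from the others in this assay.

The compounds shown are stereoisomers of one core, so they leave open whether the read-out moves at all when an amide or a methyl ester replaces the carboxylic acid, or when a longer chain is added on the amine. Also open, as far as these compounds go, is whether the remaining stereoisomers of the shared core fall within the same scatter.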